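Trimming the thioether branch: methyl removed from compound 1

The source may hold more compounds than are shown below. What is called first, only, known or untested is meant among the compounds shown, and "the series" means these compounds.

Compound 1 `Cn1ncc2c(=O)n(-c3ccccc3)c(SC(C)(C)c3ccccc3)nc21` gives 1900 nM in an assay on isolated protein for inhibition of aldehyde dehydrogenase 1A1 (Homo sapiens) (a lower number here means a stronger inhibitor, a higher number a weaker inhibitor), the higher of the two numbers measured; compound 2 `CC(Sc1nc2nn(C3(C)COC3)cc2c(=O)n1-c1ccccc1)c1ccccc1` gives 93 nM, a gap beyond the scatter. For the measured compounds named here, compound 2 shares the 1-phenylethyl group that compound 3 `CC(Sc1nc2c(cnn2C)c(=O)n1-c1ccccc1)c1ccccc1` carries, but it also differs in the group on the core, so no single step is isolated. From compound 1 to compound 3 the change is hydrogen in place of methyl on a saturated chain carbon bound to an aromatic carbon, a saturated chain carbon and a sulfur. A step toward a lower number is expected, of moderate size, estimated as a 4.2-fold lower number from compound 1 to compound 3 (0.63 log units; beyond the scatter). Compound 3 is expected to give about 450 nM, within 120 nM to 1600 nM.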

Compound 3, half-maximal inhibitory concentration: 130 nM
Estimate against measurement, compound 3: 3.5-fold (0.54 log units) above; low and high end bracket the measured number.
By their numbers in this assay, from the lowest: compounds 2 and 3 (each within the scatter of the next); then compound 1.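

Hydrogen in place of methyl on this saturated chain carbon gives a 15-fold lower number from compound 1 to compound 3 (1.16 log units; beyond the scatter) in this assay and is the first step in the series isolated to one place. For the compounds shown here, compound 2 carries the same 1-phenylethyl group but also differs in the group on the core, so only this pair ties the change to the 1-methyl-1-phenylethyl to 1-phenylethyl difference alone. No measurement at hand accounts for the size of this step. Open, as far as these compounds go, is whether this carbon accepts an ethyl, a hydroxyl or an amine in place of hydrogen.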